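A few compounds are considered here, and "the series" means these few. Any claim that something is new, unique, unknown or untested is made for them only; others in the source may bear on it.

Compound 1 `COc1ccc2nc3c(nc2c1)O[C@H]1CN(C(=O)[C@H](C(C)(C)C)NC(=O)O[C@@H]2C[C@H]2CCCCC3)[C@H](C(=O)N[C@]2(C(=O)NS(=O)(=O)C3(C)CC3)C[C@H]2C(F)F)[C@@H]1C` gives 35 mL/min/kg in an ADME assay (Rattus norvegicus) for pharmacokinetics; on this read-out lower numbers stand for slow clearance and higher numbers for fast clearance. Compound 2 `CC[C@@H]1[C@@H]2CN(C(=O)[C@H](C(C)(C)C)NC(=O)O[C@@H]3C[C@H]3CCCCCc3nc4ccc(OC)cc4nc3O2)[C@@H]1C(=O)N[C@]1(C(=O)NS(=O)(=O)C2(C)CC2)C[C@H]1C(F)F` gives 21.7 mL/min/kg, and compound 3 `C=C[C@@H]1C[C@]1(NC(=O)[C@@H]1[C@H](CC)[C@@H]2CN1C(=O)[C@H](C(C)(C)C)NC(=O)O[C@@H]1C[C@H]1CCCCCc1nc3ccc(OC)cc3nc1O2)C(=O)NS(=O)(=O)C1CC1` gives 14.7 mL/min/kg, the lowest of the three numbers, with compound 2 within the scatter of it and compound 1 beyond it. Within the data shown here, the only step between measured neighbours, a 1.6-fold lower number from compound 1 to compound 2 (0.21 log units; within the scatter), is methyl in place of hydrogen on a saturated chain carbon and so does not bear on the change at hand. Compound 4 `CC[C@@H]1[C@@H]2CN(C(=O)[C@H](C(C)(C)C)NC(=O)O[C@@H]3C[C@H]3CCCCCc3nc4ccc(OC)cc4nc3O2)[C@@H]1C(=O)N[C@]1(C(=O)NS(=O)(=O)C2CC2)C[C@H]1CC` differs from compound 3 by ethyl in place of vinyl on a saturated ring carbon. Among the measured compounds shown here, no measured pair shows ethyl in place of vinyl, so no step beyond the scatter is expected in this assay. Compound 4 is estimated at 15 mL/min/kg, between 8 mL/min/kg and 28 mL/min/kg. This amounts to an expected step of a 1.0-fold higher number from compound 3 to compound 4 (0.01 log units; within the scatter), within the scatter.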

Compound 4, clearance: 11.2 mL/min/kg
Compound 4: middle estimate off by 1.3-fold (0.13 log units), on the high side, within the range that was stated.
By their numbers in this assay, from the lowest: compounds 4, 3, 2 and 1 (each within the scatter of the next, the first and the last beyond it).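

In this assay, among these compounds, the step of a 1.3-fold lower number from compound 3 to compound 4 (0.12 log units; within the scatter) gives the first reading of ethyl in place of vinyl on a saturated ring carbon of the three-membered ring. In this single pair, losing the double bond outside aromatic rings leaves the clearance number within the scatter, so this position accepts either two-carbon group in this assay without a step beyond it. No measured evidence accounts for this result. From the compounds shown here alone, whether a propyl chain or an aminomethyl group on this ring carbon would stay in the same range remains open. Also open, going by these compounds, is whether ethyl and vinyl match on another core.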